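Fluorine on the pendant phenyl in an amide series

The source may hold more compounds than are shown below. What is called first, only, known or untested is meant among the compounds shown, and "the series" means these compounds.

Measured so far:
compound 1 `O=C(Nc1ccc(Oc2ccnc3[nH]ccc23)c(F)c1)c1cc2cccnc2n(-c2ccc(F)cc2)c1=O` — 87 nM
compound 2 `Cn1ccc2c(Oc3ccc(NC(=O)c4cc5cccnc5n(-c5ccc(F)cc5)c4=O)cc3)ccnc21` — 260 nM
compound 3 `Cn1ccc2c(Oc3ccc(NC(=O)c4cc5cccnc5n(-c5ccccc5)c4=O)cc3F)ccnc21` — 550 nM

In a functional assay on NCI-H460 cells (Homo sapiens) for antiproliferative activity, read by MTT assay, with a stated time of 72 h (a higher number here means a weaker inhibitor, a lower number a stronger inhibitor), compound 3 gives 550 nM, the highest of the three numbers. Compound 2 stands nearest to it; in this assay compound 2 gives 260 nM, a gap that lies beyond the scatter. Compound 1 lies furthest away; in this assay compound 1 gives 87 nM. Among the measured compounds shown here, no pair among the three differs in a single place, so no step between measured compounds can be read off.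

Compound 4 `Cn1ccc2c(Oc3ccc(NC(=O)c4cc5cccnc5n(-c5ccc(F)cc5)c4=O)cc3F)ccnc21` is not yet measured. It differs from compound 3 by fluoro in place of hydrogen on an aromatic carbon, para to a large group. Both compound 2 and compound 1 carry this fluoro and both give lower numbers than compound 3, though each also differs from compound 3 elsewhere. On that basis a modest step to a lower number is expected, a 1.8-fold lower number from compound 3 to compound 4 (0.26 log units; within the scatter). Compound 4 is estimated at 300 nM in this assay, with a range from 120 nM to 800 nM.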

Compound 4, half-maximal inhibitory concentration: 250 nM
For compound 4 the middle estimate is 1.2-fold (0.08 log units) above the measured one; the measured number falls inside the stated range.
By their numbers in this assay, from the lowest: compound 1; then compounds 4 and 2 (each within the scatter of the next); then compound 3.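

In this assay, among the compounds shown here, phenyl to 4-fluorophenyl can now be read as a single change (a 2.2-fold lower number from compound 3 to compound 4 (0.34 log units; beyond the scatter)), a modest step, whereas the earlier compounds carrying this fluoro also differed from compound 3 elsewhere. The other aromatic fluoro, carried by compound 4 and absent from compound 2, gives no step beyond the scatter (a 1.0-fold lower number from compound 2 to compound 4 (0.02 log units; within the scatter)), while methyl in place of hydrogen on the aromatic nitrogen gives a modest step to a higher number (a 2.9-fold higher number from compound 1 to compound 4 (0.46 log units; beyond the scatter)). No measurement shown offers an explanation for any of these steps.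

As far as these compounds go, whether the step to a lower number is specific to fluoro remains open, since chloro, methoxy or an amine at the same place would be needed to test it. Also open, from the compounds shown here alone, is how an ethyl group on the aromatic nitrogen would compare with methyl and hydrogen.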